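The source may report more compounds than this note shows. Statements on the series, on what has been measured and on what is new or still open speak of the compounds shown alone.

In a physicochemical assay for solubility (on this read-out higher numbers stand for higher solubility and lower numbers for lower solubility), compound 2 (`CNC(=O)c1cc(C(=O)NC2CCOCC2)cn(Cc2ccccc2)c1=O`) stands at >= 174 ug/mL as a limit and not a number. Compound 1 (`CNC(=O)c1cc(C(=O)NC2CC2)cn(Cc2ccc(OC)cc2)c1=O`) reads >= 143 ug/mL which is likewise a limit. Compound 3 (`CNC(=O)c1cc(C(=O)NC2CC2)cn(Cc2cccc3[nH]ccc23)c1=O`) gives 78 ug/mL as a true number. Compound 4 (`CNC(=O)c1cc(C(N)=O)cn(Cc2ccccc2)c1=O`) departs from compound 2 by hydrogen in place of oxan-4-yl on an amide-type nitrogen and this is hydrogen in place of oxan-4-yl on an amide-type nitrogen. For the measured compounds named here, the only measured step is an at least 1.8-fold lower number from compound 1 to compound 3 (0.26 log units; that floor lies within the scatter) and it lies at another place, so it bears only loosely on this change. A step of similar modest size toward lower numbers is expected in this assay and no larger shift can be argued. The estimated step is an at least 1.7-fold lower number from compound 2 to compound 4 (0.24 log units; that floor lies within the scatter) as a rough expectation. For compound 4 the estimate is 100 ug/mL with an expected range from 35 ug/mL to 170 ug/mL in this read-out.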

Compound 4, solubility: 71 ug/mL
For compound 4 the middle estimate is 1.4-fold (0.15 log units) above the measured one; low and high end bracket the measured number.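

On the amide-type nitrogen, hydrogen in place of oxan-4-yl gives an at least 2.4-fold lower number from compound 2 to compound 4 (0.38 log units; beyond the scatter) in this assay. This is the only step shown at this position, and unlike the step at the other place, it is printed as beyond the scatter. Compound 2 sits at a limit and not a number, which leaves this step a floor: the limit of >= 174 ug/mL in this assay, at which 1 of the 4 values shown sits.

On these data alone, how an aminoethyl chain or a chain ending in a carboxylic acid on this nitrogen would read in this assay stays open. As far as these compounds go, the full size of the step also stays open.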